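The source may hold more compounds than are shown below. What is called first, only, known or untested is meant among the compounds shown, and "the series" means these compounds.

Working notes on the sulfonyl series. All compounds keep the shared core of compound 1 `CCN(Cc1ccccc1)C(=O)C1CCN(S(=O)(=O)c2ccccc2)CC1` and differ only in the group on the sulfonyl sulfur. In a functional assay on CHO cells for positive allosteric modulation of muscarinic acetylcholine receptor M5 (Homo sapiens), read by calcium flux (a lower number here means that less compound is needed, a higher number that more compound is needed for the effect), compound 1 gives 6170 nM; 6200 nM (2 entries) (the several entries of compound 1 in this assay, 6170 nM; 6200 nM (2 entries)). Compound 2 `CCN(Cc1ccccc1)C(=O)C1CCN(S(=O)(=O)c2cccc3c2OCCO3)CC1` returns only a limit of this assay, > 10000 nM; > 10000 nM (2 entries). Compound 3 `CCN(Cc1ccccc1)C(=O)C1CCN(S(=O)(=O)c2c[nH]cn2)CC1` likewise stands at a limit in this assay, > 10000 nM, so no number places it against the others (the limit of > 10000 nM in this assay, at which 1 of the 3 values shown sits). The next change is pyridin-4-yl in place of 1H-imidazol-4-yl on a sulfonyl sulfur, giving compound 4 `CCN(Cc1ccccc1)C(=O)C1CCN(S(=O)(=O)c2ccncc2)CC1`. For the measured compounds named here, no measured pair isolates this change; compound 1 sits in the measurable range while compound 3 does not. For compound 4 a shift toward a measurable value is expected, an at least 1.1-fold lower number from compound 3 to compound 4 (0.04 log units; that floor lies within the scatter), with a real chance that only a limit is returned. The estimate for compound 4 is 9000 nM, between 4000 nM and 20000 nM.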

Compound 4, half-maximal effective concentration: > 10000 nM
Compound 4 gave a limit, no number; the forecaster's own chance of this, stated with the estimate: 50%; at least 1.1-fold (0.04 log units) between middle value and limit.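

Compound 4 returns only a limit in this assay, > 10000 nM. Compound 3 also stands at a limit, > 10000 nM, so no step can be read between them. On these data alone, whether pyridin-4-yl and 1H-imidazol-4-yl differ on the sulfonyl sulfur stays open.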